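A few compounds are considered here, and "the series" means these few. Any claim that something is new, unique, unknown or untested is made for them only; others in the source may bear on it.

Measured so far in a functional assay on SK-MEL-5 cells (Homo sapiens) for inhibition, read by sulforhodamine B assay, with a stated time of 48 h; on this read-out lower numbers stand for stronger inhibition of growth and higher numbers for weaker inhibition of growth:
compound 1, `O=C(Nc1cccc(-n2cc(-c3ccncc3)c(-c3ccc(Cl)c(O)c3)n2)c1)Nc1cccc(C(F)(F)F)c1`: 1300 nM
compound 2, `O=C(Nc1cccc(-n2cc(-c3ccncc3)c(-c3ccc(Cl)c(O)c3)n2)c1)Nc1ccc(Cl)c(Cl)c1`: 570 nM
compound 3, `COc1cc(-c2nn(-c3cccc(NC(=O)Nc4ccc(Cl)c(C(F)(F)F)c4)c3)cc2-c2ccncc2)ccc1Cl`: 818 nM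

Compound 3 sits between the numbers of compound 2 and compound 1, and both gaps lie within the scatter. Among the compounds with values here, the one measured step, a 2.3-fold lower number from compound 1 to compound 2 (0.36 log units; beyond the scatter), changes the aryl on the urea nitrogen and says nothing about the oxygen on the other aromatic ring.

Compound 4, `O=C(Nc1cccc(-n2cc(-c3ccncc3)c(-c3ccc(Cl)c(O)c3)n2)c1)Nc1ccc(Cl)c(C(F)(F)F)c1`, differs from compound 3 by hydrogen in place of methyl on an oxygen on an aromatic ring. Within the data shown here, no measured pair shows this change. Compounds 1 and 2 carry the hydroxy and bracket compound 3 on either side, so no step beyond the scatter is expected: a 1.3-fold lower number from compound 3 to compound 4 (0.10 log units; within the scatter). Compound 4 is estimated at 650 nM, range 300 nM to 1400 nM.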

Compound 4, concentration for 50% growth inhibition: 550 nM
The estimate for compound 4 lay 1.2-fold (0.07 log units) above the measured number; the range from low to high includes it.
By their numbers in this assay, from the lowest: compounds 4, 2, 3 and 1 (each within the scatter of the next, the first and the last beyond it).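

In this assay the change from methoxy to hydroxy can now be read directly, and a 1.5-fold lower number from compound 3 to compound 4 (0.17 log units; within the scatter) shows that the methyl on this oxygen can go without a step beyond the scatter, though this rests on one pair. On the other aryl of the urea, a 1.0-fold lower number from compound 2 to compound 4 (0.02 log units; within the scatter) leaves trifluoromethyl and chloro level, while a 2.4-fold lower number from compound 1 to compound 4 (0.37 log units; beyond the scatter) shows that chloro in place of hydrogen on an aromatic carbon gives a modest step beyond the scatter. Nothing available explains these steps.

Still open, as far as these compounds go, is whether ethoxy, an amine or a carboxylic acid on this aromatic carbon would keep the same level. Also open, from the compounds shown here alone, is whether the methoxy to hydroxy result holds with the 3,4-dichlorophenyl or 3-(trifluoromethyl)phenyl urea.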